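What One More Fluoro Might Do to Compound 1

The source may hold more compounds than are shown below. What is called first, only, known or untested is meant among the compounds shown, and "the series" means these compounds.

Within the data shown here, in a functional assay on MCF7 cells (Homo sapiens) for antiproliferative activity, read by MTT assay, with a stated time of 48 h (on this read-out higher numbers stand for weaker inhibition and lower numbers for stronger inhibition), compound 1 (`Fc1ccc2[nH]c(-c3cn(-c4ccccc4)nc3-c3ccccc3)nc2c1`) gives 2430 nM, the lower of the two numbers known so far and therefore the stronger inhibition. Among the measured compounds shown here, its only measured neighbour, compound 2 (`Cc1ccc2[nH]c(-c3cn(-c4ccccc4)nc3-c3ccccc3)nc2c1`), gives 5940 nM, and carries methyl in place of fluoro on an aromatic carbon.

Compound 3 (`Fc1ccc(-c2nn(-c3ccccc3)cc2-c2nc3cc(F)ccc3[nH]2)cc1`) keeps the whole of compound 1 and changes another place: fluoro in place of hydrogen on an aromatic carbon. This is fluoro in place of hydrogen on an aromatic carbon, para to a large group, so that phenyl becomes 4-fluorophenyl.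

For the measured compounds named here, only one measured step bears on this, and it does so loosely, since it sits elsewhere on the molecule and no change at this carbon has been measured. Going by the modest size of a 2.4-fold higher number from compound 1 to compound 2 (0.39 log units; beyond the scatter), a step of similar or smaller size is expected in this assay, with no firm direction and quite possibly none beyond the scatter.

The estimated change is a 1.1-fold lower number from compound 1 to compound 3 (0.04 log units; within the scatter). For compound 3 the expected value is 2200 nM, with an estimated range of 900 nM to 5200 nM.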

Compound 3, half-maximal inhibitory concentration: 950 nM
Estimate against measurement, compound 3: 2.3-fold (0.36 log units) above, and the stated range covers the measured number.
By their numbers in this assay, from the lowest: compound 3; then compound 1; then compound 2.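

Turning phenyl into 4-fluorophenyl, on an aromatic carbon para to a large group, gives a 2.6-fold lower number from compound 1 to compound 3 (0.41 log units; beyond the scatter) in this assay and so lies beyond the usual scatter of repeated measurements. Among these compounds, until now, the only measured change was elsewhere on the molecule, so this is the first sign that this part of compound 1 also responds to substitution, with a single added fluoro producing a modest step towards stronger inhibition. Nothing available explains why this one atom has that effect on the read-out.

Going by these compounds, a single replacement at one carbon cannot show whether the response depends on fluoro itself, so it remains open whether chloro, methoxy, an amine or a carboxylic acid at the same place would lower the number, raise it or leave it unchanged. On these data alone, it is also open whether the same phenyl to 4-fluorophenyl change would produce a step of similar size on compound 2, which carries methyl where compound 1 carries fluoro.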